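Piperazine N-substituent step in a cytotoxicity series

The source may hold more compounds than are shown below. What is called first, only, known or untested is meant among the compounds shown, and "the series" means these compounds.

The set shares one core, carried by compound 1 `Fc1ccc(N2CCN(Cn3nc(-c4ccncc4)oc3=S)CC2)cc1`, compound 2 `CN1CCN(Cn2nc(-c3ccncc3)oc2=S)CC1`, compound 3 `FC(F)(F)c1ccccc1N1CCN(Cn2nc(-c3ccncc3)oc2=S)CC1` and the still unmeasured compound 4 `CCN1CCN(Cn2nc(-c3ccncc3)oc2=S)CC1`. In an ADME assay on MCF7 cells (Homo sapiens) for cytotoxicity, read by MTT assay, with a stated time of 48 h (on this read-out lower numbers stand for stronger inhibition and higher numbers for weaker inhibition), compound 1 gives only a limit of the assay, > 250000 nM, and no number. In this assay compound 2 gives "not determined" (no result reported). In this assay compound 3 gives "not determined" (no result reported). Within the data shown here, compound 2 therefore stands without a number of its own; the single value shown is a limit, and no step between measured compounds can be read. The change from compound 2 to compound 4 is methyl in place of hydrogen on a saturated chain carbon bound to an amine nitrogen in a ring. Among the measured compounds shown here, with no measured step to lean on, no shift in this assay is expected beyond the scatter, in either direction. For compound 4 the value in this assay is estimated at 200000 nM, within a range of 50000 nM to 600000 nM, with a fair chance that only a limit is reported.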

Compound 4, half-maximal inhibitory concentration: > 250000 nM
Compound 4: only a limit was reported (the forecaster's own chance of this, stated with the estimate: 65%); at least 1.2-fold (0.09 log units) between middle value and limit.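

No new step can be read in this assay, where compound 1 and compound 4 each give only a limit of the assay and the step between them stays unreadable: the limit of > 250000 nM in this assay, at which 2 of the 4 values shown sit.

The compounds shown leave open whether ethyl and 4-fluorophenyl on an amine nitrogen in a ring differ at all on this read-out.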